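Swapping the Amide Ring: Methoxy Out, Chloro-Fluoro In

A few compounds are considered here, and "the series" means these few. Any claim that something is new, unique, unknown or untested is made for them only; others in the source may bear on it.

Of the compounds shown here, two have so far been measured in an ADME assay on HUVEC cells (Homo sapiens) for cytotoxicity, read by MTT assay, with a stated time of 72 h; on this read-out higher numbers stand for weaker inhibition and lower numbers for stronger inhibition. Compound 2 `COc1ccc(NC(=O)CCC(=O)OCCCCCCSc2ccc([N+](=O)[O-])c3nonc23)cc1` gives 1590 nM, and compound 1 `O=C(CCC(=O)OCCCCCCSc1ccc([N+](=O)[O-])c2nonc12)Nc1cccc(Cl)c1` gives 1090 nM; the step of a 1.5-fold higher number from compound 1 to compound 2 (0.16 log units; within the scatter) lies within the scatter, so the two cannot be told apart on these numbers. Compound 3 `O=C(CCC(=O)OCCCCCCSc1ccc([N+](=O)[O-])c2nonc12)Nc1ccc(F)c(Cl)c1` differs from compound 2 by 3-chloro-4-fluorophenyl in place of 4-methoxyphenyl on an amide-type nitrogen. Within the data shown here, the one measured step also exchanged one substituted phenyl for another on the same amide-type nitrogen and stayed within the scatter, so little movement is expected in this assay here. Compound 3 is therefore estimated at 1200 nM, within 600 nM to 2400 nM. That would be an expected step of a 1.3-fold lower number from compound 2 to compound 3 (0.12 log units; within the scatter).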

Compound 3, half-maximal inhibitory concentration: 2320 nM
Compound 3: the middle estimate sits 1.9-fold (0.29 log units) below what was measured; the measured number falls inside the stated range.
By their numbers in this assay, from the lowest: compounds 1, 2 and 3 (each within the scatter of the next, the first and the last beyond it).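

In this assay, among these compounds, fluoro in place of hydrogen on an aromatic carbon gives the first step beyond the scatter, though a modest one (a 2.1-fold higher number from compound 1 to compound 3 (0.33 log units; beyond the scatter)). The larger exchange on the amide-type nitrogen stays within the scatter (a 1.5-fold higher number from compound 2 to compound 3 (0.16 log units; within the scatter)), so 4-methoxyphenyl and 3-chloro-4-fluorophenyl cannot be told apart here. No measured evidence bears on this result. Going by these compounds, whether fluoro shifts the number similarly on other phenyl rings remains open. So does the effect of an amine or a carboxylic acid on this ring.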